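A few compounds are considered here, and "the series" means these few. Any claim that something is new, unique, unknown or untested is made for them only; others in the source may bear on it.

Compound 1 `COc1ccc(NC(=O)c2cc(N(C)Cc3ccccc3)ncn2)cc1` gives < 5000 nM in a physicochemical assay for solubility, using the shake flask method, measured as kinetic solubility, with a stated time of 2 h, at pH 7.4 (on this read-out higher numbers stand for higher solubility and lower numbers for lower solubility), a limit.
Compound 2 `CN(Cc1ccccc1)c1cc(C(=O)Nc2ccccc2)ncn1` gives < 5000 nM in this assay, a limit.
Compound 3 `CN(Cc1ccc(C#N)cc1)c1cc(C(=O)Nc2ccccc2)ncn1` gives < 5000 nM in this assay, a limit.

Compound 2 stands only at a limit in this assay, as do its two neighbours: the limit of < 5000 nM in this assay, at which 3 of the 3 values shown sit. The two measured steps, a step that the two limits leave unreadable from compound 1 to compound 2 and a step that the two limits leave unreadable from compound 2 to compound 3, therefore give no readable size. Compound 4 `CN(Cc1cccnc1)c1cc(C(=O)Nc2ccccc2)ncn1` differs from compound 2 by pyridin-3-yl in place of phenyl on a saturated chain carbon bound to a nitrogen on an aromatic ring. Within the data shown here, no measured step touches this change, so the expected step of a number no lower from compound 2 to compound 4 (the limit leaves the size open) rests on nothing but the shared limit. Compound 4 is accordingly estimated at 5000 nM, within 1500 nM to 20000 nM, in this assay.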

Compound 4, solubility: 150000 nM
Compound 4: the middle estimate sits 30-fold (1.48 log units) below what was measured; the measured number lies above the stated range.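

In this assay, the place on the saturated chain carbon bound to a nitrogen on an aromatic ring gives the first readable change: pyridin-3-yl in place of phenyl gives an at least 30-fold higher number from compound 2 to compound 4 (1.47 log units; beyond the scatter), and pyridin-3-yl in place of 4-cyanophenyl gives an at least 30-fold higher number from compound 3 to compound 4 (1.47 log units; beyond the scatter). On these data alone, both steps start from a limit, so their true sizes stay open. Compound 4 is the only compound shown clear of that shared limit: the limit of < 5000 nM in this assay, at which 3 of the 4 values shown sit.

The compounds shown leave open whether pyridin-2-yl, pyridin-4-yl or an amine such as morpholine would do the same in this place. They also leave open whether the methoxy group of compound 1 would keep so high a number alongside pyridin-3-yl.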